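Exchange of the amide nitrogen substituent in compound 1

The source may report more compounds than this note shows. Statements on the series, on what has been measured and on what is new or still open speak of the compounds shown alone.

Three compounds of the series have numbers in an assay on HEK293 cells for agonist activity at transient receptor potential cation channel subfamily M member 8 (Homo sapiens), read by fluorescence and calcium flux, with a stated time of 15 min; on this read-out lower numbers stand for an effect already at smaller amounts and higher numbers for an effect only at larger amounts of compound. Compound 1 `Cc1ccc(OCC(=O)N(Cc2cccs2)c2cccnc2)cc1` gives 198 nM in this assay. Compound 2 `CCN(Cc1ccsc1)C(=O)COc1ccc(C)cc1` gives 88 nM in this assay, and compound 3 `CCN(Cc1cccs1)C(=O)COc1ccc(C(C)C)cc1` gives 397 nM in this assay. Among these three numbers compound 1 stands second highest: the value of compound 3 is the nearest, a gap within the usual scatter, so the two cannot be told apart; the value of compound 2 is the furthest, a gap beyond the scatter, so compound 2 acts at smaller amounts than compound 1. Compounds 2 and 3 differ from compound 1 in more than one place, so no single change can be read from them.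

Compound 4 `Cc1ccc(OCC(=O)N(Cc2cccs2)c2cnn(C)c2)cc1` has not been measured. It differs from compound 1 in one place: 1-methyl-1H-pyrazol-4-yl in place of pyridin-3-yl on an amide-type nitrogen. Among the measured compounds shown here, no pair of measured compounds shows this change alone, so its size is not known from the data. The step from compound 1 to compound 4 in this assay is expected to be small, most likely within the scatter or a modest move toward a higher number. For compound 4 the number in this assay is estimated at 300 nM, with a range from 110 nM to 850 nM, meaning an expected step of a 1.5-fold higher number from compound 1 to compound 4 (0.18 log units; within the scatter).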

Compound 4, half-maximal effective concentration: 63000 nM
The estimate for compound 4 lay 210-fold (2.32 log units) below the measured number, outside the stated range (above it).
By their numbers in this assay, from the lowest: compound 2; then compounds 1 and 3 (each within the scatter of the next); then compound 4.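

Notes on the position: in this assay, the aromatic ring on the amide-type nitrogen proves highly sensitive to exchange, with a 320-fold higher number from compound 1 to compound 4 (2.50 log units; beyond the scatter) arising from this single replacement of pyridin-3-yl by 1-methyl-1H-pyrazol-4-yl. The step occurs although the heavy-atom count stays the same, neither group has a hydrogen-bond donor and neither carries a net charge, so these counted features alone do not predict the outcome at this place; compounds 2 and 3 could not show this, as each differs from compound 1 in more than one place. Nothing measured on these compounds accounts for the size of the step.

Still open, as far as these compounds go, is which part of the change matters: the five-membered ring, the second ring nitrogen or the methyl group, a question that 1H-pyrazol-4-yl, pyridin-4-yl or phenyl on the same nitrogen would help separate. Also open, from the compounds shown here alone, is whether a step of this size would recur with the same exchange in a compound carrying a different group on the aromatic ether, such as isopropyl in place of methyl.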